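A few compounds are considered here, and "the series" means these few. Any claim that something is new, unique, unknown or untested is made for them only; others in the source may bear on it.

Measured compounds in this study:

Compound 1, `O=S1(=O)N=C(NCc2ccccc2)Nc2ncccc21`, gives > 300 uM, which is a limit of the assay and not a number.

Compound 2, `C[C@H](NC1=NS(=O)(=O)c2cccnc2N1)c1ccccc1`, gives > 300 uM, again a limit.

Compound 3, `CC(C)C(C)NC1=NS(=O)(=O)c2cc(Cl)cnc2N1`, gives > 300 uM, also a limit.

All three were tested in a functional assay (ileum) for inhibition, with Cavia porcellus as the target; a lower number here means that less compound is needed, a higher number that more compound is needed for the effect. The step that the two limits leave unreadable from compound 1 to compound 2 arises from the change methyl in place of hydrogen on a saturated chain carbon bound to an amine nitrogen and an aromatic carbon and cannot be sized, since both values are limits. Compound 4, `CC(NC1=NS(=O)(=O)c2cc(Cl)cnc2N1)C(C)(C)C`, has not yet been measured; it differs from compound 3 by methyl in place of hydrogen on a saturated chain carbon bound to three saturated chain carbons. The place is not the same as in the earlier pair, where the carbon was bound to an amine nitrogen and an aromatic carbon, whereas here it is bound to three saturated chain carbons, so this is the same kind of change, not the same change. The difference between the two cores is not broken down here. Because (the limit of > 300 uM in this assay, at which 3 of the 3 values shown sit), compound 4 is expected to remain at the limit as well. For compound 4 the expected step is a step that the limit leaves unreadable from compound 3 to compound 4. Compound 4 is estimated at 600 uM, between 150 uM and 3000 uM.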

Compound 4, concentration for half-maximal effect: > 300 uM
Compound 4: a limit, no number (the forecaster's own chance of this, stated with the estimate: 85%); the middle value is on the limit's open side.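

Compound 3 and compound 4 both give only a limit in this assay, so no step can be read between them. The compounds shown leave open what size any structural change has, with every result resting on one limit: the limit of > 300 uM in this assay, at which 4 of the 4 values shown sit.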